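Ring swap on the aromatic-ring nitrogen of compound 1

This account rests on a few compounds, and the source may have more. Where it says the series, first, only, none or still open, it means among the compounds named here.

Measured compounds:
Compound 1 `CCCSc1nc(N/N=C/c2cccnc2)c2nnn(Cc3ccccc3)c2n1`: 38100 nM
Compound 2 `C#CCSc1nc(N/N=C/c2c(O)ccc3ccccc23)c2nnn(Cc3ccccc3)c2n1`: 10500 nM
Compound 3 `CCCSc1nc(N/N=C(\C)c2ccccc2O)c2nnn(Cc3ccc(F)cc3)c2n1`: 11000 nM

In a functional assay on MGC-803 cells (Homo sapiens) for antiproliferative activity, read by MTT assay, with a stated time of 72 h (on this read-out lower numbers stand for stronger inhibition and higher numbers for weaker inhibition), compound 1 gives the highest number of the three; compound 3 and compound 2 both sit at lower numbers, each beyond the usual scatter. Compound 4 `CCCSc1nc(N/N=C(\C)c2ccccc2)c2nnn(Cc3ccccc3)c2n1` keeps the core of compound 1 and differs from it in one place: a group of 9 heavy atoms (8 carbon, 1 nitrogen; one six-membered aromatic ring of carbon only) in place of a group of 8 heavy atoms (6 carbon, 2 nitrogen; one six-membered aromatic ring with 1 hetero atom), on a nitrogen on an aromatic ring. No measured pair differs in a single place, so the size of this step is not shown directly. A modest move toward a lower number is expected from compound 1 to compound 4, a 2.1-fold lower number from compound 1 to compound 4 (0.33 log units; beyond the scatter), which may or may not clear the scatter. Support is indirect: compound 3 also carries a six-membered aromatic ring of carbon only at that position, but differs elsewhere too. For compound 4 the expected value in this assay is 18000 nM, within 6000 nM to 50000 nM.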

Compound 4, half-maximal inhibitory concentration: 25400 nM
Compound 4: middle estimate off by 1.4-fold (0.15 log units), on the low side; low and high end bracket the measured number.
By their numbers in this assay, from the lowest: compounds 2 and 3 (each within the scatter of the next); then compounds 4 and 1 (each within the scatter of the next).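

In this assay, going by these compounds alone, the first single-place step reads a 1.5-fold lower number from compound 1 to compound 4 (0.18 log units; within the scatter). On this nitrogen on an aromatic ring, the group with a six-membered aromatic ring of carbon only therefore cannot be told apart from the group with a six-membered aromatic ring with 1 hetero atom. No available evidence bears on this result.

Within the data shown here, compound 2 and compound 3 differ from compound 4 in more than one place, so no steps to them can be read. Open, going by these compounds, is whether a group carrying an amine or a carboxylic acid at this place would give a step beyond the scatter.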